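Phenylethynyl replacing hexyl on a pyrimidinedione nucleoside

The source may hold more compounds than are shown below. What is called first, only, known or untested is meant among the compounds shown, and "the series" means these compounds.

Measured compounds:
- compound 1 `CCC#Cc1cn([C@H]2C[C@H](O)[C@@H](CO)O2)c(=O)[nH]c1=O`: > 1000 ug/mL
- compound 2 `CC#CCc1cn([C@H]2C[C@H](O)[C@@H](CO)O2)c(=O)[nH]c1=O`: > 1000 ug/mL
- compound 3 `CCCCCCc1cn([C@H]2C[C@H](O)[C@@H](CO)O2)c(=O)[nH]c1=O`: 301 ug/mL

In a functional assay on L1210 cells (Mus musculus) (on this read-out lower numbers stand for stronger inhibition and higher numbers for weaker inhibition), compound 1 gives only a limit, > 1000 ug/mL. Compound 2 likewise gives only a limit, > 1000 ug/mL. Among the compounds with values here, compound 3 is the one compound with a real number, 301 ug/mL, and so it stands as the single readable point among the three, the other two sitting at the limit of > 1000 ug/mL in this assay, at which 2 of the 3 values shown sit.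

Compound 4 `O=c1[nH]c(=O)n([C@H]2C[C@H](O)[C@@H](CO)O2)cc1C#Cc1ccccc1` has not yet been measured. It differs from compound 3 in one place: 2-phenylethynyl in place of hexyl on an aromatic carbon.

Within the data shown here, two measured steps bear on this change. From the but-1-yn-1-yl compound to the hexyl compound the number fell, an at least 3.3-fold lower number from compound 1 to compound 3 (0.52 log units; beyond the scatter), and from the prop-1-yn-1-yl chain to the pentyl chain it fell as well, an at least 3.3-fold lower number from compound 2 to compound 3 (0.52 log units; beyond the scatter). Both steps show a triple-bond group giving way to a saturated chain and the number going down. The change to compound 4 runs the other way, bringing a triple bond back in, now carrying a phenyl ring. The step in this assay is therefore expected to go upward, a 2.7-fold higher number from compound 3 to compound 4 (0.42 log units; beyond the scatter), quite possibly back to a limit. Compound 4 is expected to give 800 ug/mL, within 200 ug/mL to 3000 ug/mL.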

Compound 4, concentration for 50% inhibition: 494 ug/mL
The estimate for compound 4 lay 1.6-fold (0.21 log units) above the measured number; measured number inside the range.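

In this assay the swap of hexyl for 2-phenylethynyl gives a 1.6-fold higher number from compound 3 to compound 4 (0.22 log units; within the scatter) and so leaves the two groups indistinguishable at this position. Within the data shown here, compound 4 is also the first compound here with a triple bond to give a real number rather than a limit, so a triple bond on this aromatic carbon does not by itself put a compound at the limit. Phenyl in place of ethyl on the triple-bonded carbon gives an at least 2.0-fold lower number from compound 1 to compound 4 (0.30 log units; that floor lies within the scatter) and the change from but-2-yn-1-yl gives an at least 2.0-fold lower number from compound 2 to compound 4 (0.30 log units; that floor lies within the scatter) but the full size of both steps stays unknown because each starts from a limit: the limit of > 1000 ug/mL in this assay, at which 2 of the 4 values shown sit.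

The compounds shown leave open whether the phenyl ring or the triple bond matters more, a question that a phenyl ring carried on a saturated chain could address. They also leave open whether any group on this carbon can move the number clearly below that of compound 3, such as an octyl chain, an amine or a carboxylic acid at the end of the hexyl chain.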